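Substitution at the chain carbon of compound 1

A few compounds are considered here, and "the series" means these few. Any claim that something is new, unique, unknown or untested is made for them only; others in the source may bear on it.

Measured compounds:
- compound 1 `O=C(O)COc1cccc(CCc2nc(-c3ccccc3)c(-c3ccccc3)o2)c1`: 1200 nM
- compound 2 `C[S+]([O-])C(Cc1cccc(OCC(=O)O)c1)c1nc(-c2ccccc2)c(-c2ccccc2)o1`: 7080 nM
- compound 3 `O=C(O)COc1cccc(CC(c2nc(-c3ccccc3)c(-c3ccccc3)o2)c2cccs2)c1`: 33200 nM

In a functional assay for inhibition, with Homo sapiens as the target (on this read-out lower numbers stand for stronger inhibition and higher numbers for weaker inhibition), compound 1 gives 1200 nM, the lowest of the three numbers; its nearest neighbour is compound 2 and the furthest is compound 3. Compound 4 `O=C(O)COc1cccc(CC(CCO)c2nc(-c3ccccc3)c(-c3ccccc3)o2)c1` has not yet been measured in this assay. It differs from compound 1 as follows: 2-hydroxyethyl in place of hydrogen on a saturated chain carbon bound to an aromatic carbon and a saturated chain carbon.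

For the measured compounds named here, two measured steps bear on this change, since both place a group on the same saturated chain carbon of compound 1. The first, a 5.9-fold higher number from compound 1 to compound 2 (0.77 log units; beyond the scatter), adds a group of three heavy atoms without a ring; the second, a 28-fold higher number from compound 1 to compound 3 (1.44 log units; beyond the scatter), adds a five-membered aromatic ring. Both raise the number beyond the scatter, the ring-bearing group more than the smaller group. The 2-hydroxyethyl group entering in compound 4 matches the smaller group in heavy-atom count and carries no ring, so a step of the size seen toward compound 2 is expected rather than the larger one toward compound 3. Compound 4 is therefore expected at 4500 nM in this assay, within 1800 nM to 11000 nM, an estimated step of a 3.8-fold higher number from compound 1 to compound 4 (0.57 log units; beyond the scatter).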

Compound 4, half-maximal inhibitory concentration: 2920 nM
Compound 4: the middle estimate sits 1.5-fold (0.19 log units) above what was measured, within the range that was stated.
By their numbers in this assay, from the lowest: compound 1; then compound 4; then compound 2; then compound 3.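

In this assay, substitution on the saturated chain carbon bound to an aromatic carbon and a saturated chain carbon now has its smallest listed penalty with 2-hydroxyethyl: a 2.4-fold higher number from compound 1 to compound 4 (0.39 log units; beyond the scatter). The outcome depends on the entering group and not only on the presence of a substituent, as shown by an 11-fold lower number from compound 3 to compound 4 (1.06 log units; beyond the scatter) and by a 2.4-fold lower number from compound 2 to compound 4 (0.38 log units; beyond the scatter), even though the groups in that last pair have the same heavy-atom count. No measurement at hand accounts for these differences.

From the compounds shown here alone, whether a hydroxymethyl group, a longer 3-hydroxypropyl chain, or a chain ending in an amine or a carboxylic acid would bring the number closer to that of compound 1 remains open. A plain propyl group at this carbon would show whether the hydroxyl of 2-hydroxyethyl matters to the result.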